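This account rests on a few compounds, and the source may have more. Where it says the series, first, only, none or still open, it means among the compounds named here.

Compound 3 `Cc1nn(-c2nc(-c3ccc(Cl)c(Cl)c3)c(SC(C)C)s2)c(C(=O)O)c1-c1cnccn1` is one of three analogues around a shared core; in a functional assay on BJAB cells (Homo sapiens) for antiproliferative activity, with a stated time of 4 days (a lower number here means that less compound is needed, a higher number that more compound is needed for the effect), compound 3 gives 14000 nM, second highest of the three numbers. Compound 1 `COc1ccc(-c2c(C)nn(-c3nc(-c4ccc(Cl)c(Cl)c4)c(SC(C)C)s3)c2C(=O)O)cc1` gives 2100 nM and compound 2 `Cc1nn(-c2nc(-c3ccc(Cl)c(Cl)c3)c(SC(C)C)s2)c(C(=O)O)c1-c1cccc(C(F)(F)F)c1` gives 22000 nM. The step of a 6.7-fold higher number from compound 1 to compound 3 (0.82 log units; beyond the scatter) shows the move from 4-methoxyphenyl to pyrazin-2-yl; the step of a 1.6-fold lower number from compound 2 to compound 3 (0.20 log units; within the scatter) lies within the scatter. Compound 4 `COc1cc(Cl)cc(-c2c(C)nn(-c3nc(-c4ccc(Cl)c(Cl)c4)c(SC(C)C)s3)c2C(=O)O)c1` carries 3-chloro-5-methoxyphenyl in place of pyrazin-2-yl on an aromatic carbon. For the measured compounds named here, the only step returning to a methoxy-bearing phenyl is a 6.7-fold higher number from compound 1 to compound 3 (0.82 log units; beyond the scatter), read backwards, and the extra chlorine has no precedent here, so only a partial reversal is expected, as a 2.8-fold lower number from compound 3 to compound 4 (0.45 log units; beyond the scatter). For compound 4 the estimate is 5000 nM, with a range from 1500 nM to 16000 nM.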

Compound 4, half-maximal effective concentration: 760 nM
Beside the measured number, compound 4's estimate is 6.6-fold (0.82 log units) above it; measured number outside the range, below it.
By their numbers in this assay, from the lowest: compound 4; then compound 1; then compounds 3 and 2 (each within the scatter of the next).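

In this assay, for the compounds shown here, 3-chloro-5-methoxyphenyl in place of pyrazin-2-yl gives an 18-fold lower number from compound 3 to compound 4 (1.27 log units; beyond the scatter), and in place of 3-(trifluoromethyl)phenyl it gives a 29-fold lower number from compound 2 to compound 4 (1.46 log units; beyond the scatter), so this position spans a wider range than the earlier compounds showed. It also goes past 4-methoxyphenyl, with a 2.8-fold lower number from compound 1 to compound 4 (0.44 log units; beyond the scatter), which therefore no longer holds the lowest number. The compounds shown do not separate the contribution of the chlorine from that of the moved methoxy group, and they leave open how a phenyl bearing an amine or a hydroxy group would read here. Nothing at hand explains these steps.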